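The source may hold more compounds than are shown below. What is called first, only, known or untested is meant among the compounds shown, and "the series" means these compounds.

Working notes on the series. Compound 1 `O=C(Nc1cc(Cl)cc(Cl)c1)c1cnc(O)nc1C(F)(F)F` and compound 2 `O=C(Nc1cc(Cl)cc(Cl)c1)c1cncnc1C(F)(F)F` carry a shared core; compound 3 `NC(=O)c1cc(NC(=O)c2cnc(Cl)nc2C(F)(F)F)cc(C(F)(F)F)c1` carries the same core with a chlorine on it, and compound 4 `O=C(OC1CCCCC1)c1cc(NC(=O)c2cnc(Cl)nc2C(F)(F)F)cc(C(F)(F)F)c1` is the next member, still unmeasured. In an assay on Jurkat cells for inhibition of cyclic AMP-dependent transcription factor ATF-1 (Homo sapiens) (a lower number here means a stronger inhibitor, a higher number a weaker inhibitor), compound 1 gives only a limit, > 10000 nM. In this assay compound 2 also gives only a limit, > 10000 nM. The step that the two limits leave unreadable from compound 1 to compound 2 is therefore not readable. Two of the three values sit at the limit of > 10000 nM in this assay, at which 2 of the 3 values shown sit. In this assay, among the measured compounds shown here, compound 3 gives 3000 nM, the only actual number in the set, so compound 3 is the sole anchor for what follows.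

The move to compound 4 is cyclohexyloxy in place of amino on a carbonyl carbon. For the measured compounds named here, no measured step touches this position: the single measured step concerns the hydroxy on the core and is itself unreadable, so no direction beyond the scatter can be derived from the data. The expected step is no change at the digits printed from compound 3 to compound 4 (within the scatter). For compound 4 the estimate in this assay is 3000 nM, with a range from 600 nM to 15000 nM, the width reflecting the absence of any bearing step.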

Compound 4, half-maximal inhibitory concentration: 1200 nM
Estimate against measurement, compound 4: 2.5-fold (0.40 log units) above; the measured number falls inside the stated range.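

In this assay, among the compounds shown here, cyclohexyloxy in place of amino on a carbonyl carbon gives a 2.5-fold lower number from compound 3 to compound 4 (0.40 log units; beyond the scatter), the first readable step, as the earlier step between two limits cannot be read. This position therefore accepts carbamoyl giving way to cyclohexyloxycarbonyl, with its six-membered non-aromatic ring and without the hydrogen-bond donor of the amino group, and the number does not rise. Nothing at hand gives a reason for this step.

From the compounds shown here alone, whether the lower number belongs to the ester link, to the cyclohexyl ring or to the loss of the amino group stays open, and a single step does not separate these. Going by these compounds, how a methyl ester, a phenyl ester or a carboxylic acid would read at this carbonyl carbon is also open.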